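Removing the chloro from compound 1: an expectation

The source may report more compounds than this note shows. Statements on the series, on what has been measured and on what is new or still open speak of the compounds shown alone.

Of the compounds shown here, two with a shared core have been tested. Compound 1 `CC(C)c1ccc(-c2nc(SCc3cn(CC(=O)NC(=O)Nc4ccccn4)nn3)nc(Nc3ccccc3Cl)c2C#N)cc1` and compound 2 `CC(C)c1ccc(-c2nc(SCc3cn(CC(=O)NC(=O)Nc4ccccn4)nn3)nc(Nc3cccc([N+](=O)[O-])c3)c2C#N)cc1` differ in the aryl group attached to a nitrogen on an aromatic ring. In a functional assay on MCF7 cells (Homo sapiens) for inhibition, read by MTT assay, with a stated time of 72 h (a higher number here means a weaker inhibitor, a lower number a stronger inhibitor), compound 1 gives 43700 nM, the higher of the two numbers, and compound 2 gives 25900 nM; the change a 1.7-fold lower number from compound 1 to compound 2 (0.23 log units; within the scatter) does not stand out from repeat-to-repeat variation. Compound 3 `CC(C)c1ccc(-c2nc(SCc3cn(CC(=O)NC(=O)Nc4ccccn4)nn3)nc(Nc3ccccc3)c2C#N)cc1` is not yet measured. It differs from compound 1 by hydrogen in place of chloro on an aromatic carbon. For the measured compounds named here, only the step from compound 1 to compound 2 bears on this, and it was small; no measured pair removes a chloro on this ring, so the expectation rests on the shared core behaving alike. The expected step of a 1.1-fold lower number from compound 1 to compound 3 (0.04 log units; within the scatter) is therefore none beyond the scatter. Compound 3 is estimated at 40000 nM, with a range from 15000 nM to 100000 nM.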

Compound 3, half-maximal inhibitory concentration: > 64000 nM
Compound 3 was reported as a limit (the forecaster's own chance of this, stated with the estimate: 15%); middle value at least 1.6-fold (0.20 log units) away from the limit.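

Compound 3, which carries hydrogen where the other two carry a group on this ring, is reported in this assay only as a limit of the assay and not as a number: the limit of > 64000 nM in this assay, at which 1 of the 3 values shown sits.

Even so, swapping the nitro group for hydrogen gives an at least 2.4-fold higher number from compound 2 to compound 3 (0.39 log units; beyond the scatter), the first step in this small set to clear the scatter, so a group on this ring can matter here. Swapping the chloro for hydrogen gives an at least 1.4-fold higher number from compound 1 to compound 3 (0.16 log units; that floor lies within the scatter), and that floor alone cannot show whether the chloro itself matters.

Going by these compounds, how far the true value of compound 3 lies past the limit remains open, and with it the real size of both steps. Also open, on these data alone, is how a methoxy group or an amine on this ring would compare with the nitro group.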